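From bromo to iodo on a shared core

A few compounds are considered here, and "the series" means these few. Any claim that something is new, unique, unknown or untested is made for them only; others in the source may bear on it.

In a functional assay on MCF7 cells (Homo sapiens) for cytotoxicity, read by MTT assay, with stated times of 3 h and 24 h (on this read-out lower numbers stand for stronger inhibition and higher numbers for weaker inhibition), compound 1 `COc1ccc(C2=[N+]3C(=Nc4c(-c5ccccc5)c5c(n4[B-]3(F)F)-c3ccc(OC)cc3CC5)C(c3ccccc3)=C2Br)cc1` gives 4500 nM and compound 2 `COc1ccc2c(c1)CCc1c(-c3ccccc3)c3n(c1-2)[B-](F)(F)[N+]1=C(c2ccc(C)cc2)C(Br)=C(c2ccccc2)C1=N3` gives 8100 nM. These two numbers are the only exact ones so far, and they agree within the scatter, with a step of a 1.8-fold higher number from compound 1 to compound 2 (0.26 log units; within the scatter). Compound 3 `COc1ccc2c(c1)CCc1c(-c3ccccc3)c3n(c1-2)[B-](F)(F)[N+]1=C(c2ccc(C)s2)C(Br)=C(c2ccccc2)C1=N3` reads > 25000 nM, which is a limit of the assay and not a number. Placing 5-methylthiophen-2-yl on the carbon with a double bond to nitrogen gives larger steps: an at least 5.5-fold higher number from compound 1 to compound 3 (0.74 log units; beyond the scatter) and an at least 3.0-fold higher number from compound 2 to compound 3 (0.48 log units; beyond the scatter).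

Compound 4 `COc1ccc2c(c1)CCc1c(-c3ccccc3)c3n(c1-2)[B-](F)(F)[N+]1=C(c2ccc(C)cc2)C(I)=C(c2ccccc2)C1=N3` differs from compound 2 at another place: iodo in place of bromo on a double-bonded ring carbon. Going by the values given here, no measured step changes this halogen, so the steps above offer only a rough sense of scale. Starting from compound 2 at 8100 nM, no step beyond the scatter is expected in this assay. The estimated change is a 1.1-fold lower number from compound 2 to compound 4 (0.03 log units; within the scatter). Compound 4 is expected at 7500 nM, within an estimated range of 3000 nM to 20000 nM.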

Compound 4, half-maximal inhibitory concentration: 410 nM
Estimate against measurement, compound 4: 18-fold (1.26 log units) above; the measured number lies below the stated range.
By their numbers in this assay, from the lowest: compound 4; then compounds 1 and 2 (each within the scatter of the next). At a limit, above all of these: compound 3.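

Earlier steps changed only the group on the carbon with a double bond to nitrogen or the methoxy and methyl ends of an aryl group, whereas in this assay iodo in place of bromo on a double-bonded ring carbon gives a 20-fold lower number from compound 2 to compound 4 (1.30 log units; beyond the scatter) and shows that this position responds strongly to its halogen. The two groups count the same under heavy atoms, and neither brings a ring, a hydrogen-bond donor, a hydrogen-bond acceptor or a net charge, so this large step comes from a change in the halogen alone. The single line of background on hand concerns the assay limit and offers no explanation for this step.

Going by these compounds, whether iodo acts in the same way alongside the 4-methoxyphenyl group of compound 1 or the 5-methylthiophen-2-yl group of compound 3 remains open. Also open, on these data alone, is what chloro, an amine or a longer chain would give on this ring carbon.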